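The source may hold more compounds than are shown below. What is called first, only, known or untested is meant among the compounds shown, and "the series" means these compounds.

In a functional assay on A549 cells (Homo sapiens) for cytotoxicity, read by sulforhodamine B assay, with a stated time of 48 h (on this read-out lower numbers stand for stronger inhibition and higher numbers for weaker inhibition), compound 1 (`COc1ccc(/C=C/C(=O)c2cccc(-c3ccc(F)cc3)c2)cc1`) gives 11200 nM, the middle of three values. Compound 2 (`COc1ccc(/C=C/C(=O)c2cccc(Br)c2)cc1`) gives 34200 nM and compound 3 (`COc1ccc(/C=C/C(=O)c2cccc(-c3cccc(F)c3)c2)cc1`) gives 2440 nM. Compound 4 (`COc1ccc(/C=C/C(=O)c2cccc(-c3ccc(F)cc3)c2)cc1OC`) differs from compound 1 by one change: methoxy in place of hydrogen on an aromatic carbon, ortho to a methoxy group. The measured steps are a 3.1-fold higher number from compound 1 to compound 2 (0.48 log units; beyond the scatter), a 4.6-fold lower number from compound 1 to compound 3 (0.66 log units; beyond the scatter) and a 14-fold lower number from compound 2 to compound 3 (1.15 log units; beyond the scatter). All three exchange a different substituent, so none tests this change directly. Among the compounds with values here, they show only that one exchange on the shared core can shift the number. No clear direction can be drawn from them, so little movement beyond the scatter is expected in this assay. The estimated step is a 1.2-fold lower number from compound 1 to compound 4 (0.09 log units; within the scatter). For compound 4 the expected value is 9000 nM, with an estimated range of 3000 nM to 30000 nM.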

Compound 4, half-maximal inhibitory concentration: 11800 nM
Estimate against measurement, compound 4: 1.3-fold (0.12 log units) below; low and high end bracket the measured number.
By their numbers in this assay, from the lowest: compound 3; then compounds 1 and 4 (each within the scatter of the next); then compound 2.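

In this assay, methoxy in place of hydrogen on the aromatic carbon ortho to a methoxy group gives a 1.1-fold higher number from compound 1 to compound 4 (0.02 log units; within the scatter) and so does not shift the number. Within the data shown here, this is the first direct test of this position, as the earlier steps exchanged only the other substituent. No measurement shown offers an explanation for this result.

On these data alone, whether methoxy behaves the same way on the core of compound 3, with its 3-fluorophenyl group, remains open. So does the effect of an amine or a carboxylic acid at this position.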